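The source may report more compounds than this note shows. Statements on the series, on what has been measured and on what is new or still open speak of the compounds shown alone.

In an ADME assay on the whole organism (plasma) for pharmacokinetics, with Rattus norvegicus as the target (on this read-out lower numbers stand for slow clearance and higher numbers for fast clearance), compound 1 (`CC1(C)CC2(CCN(C(=O)c3ccc(C[C@@H]4CC[C@H]([C@H](O)c5ccccc5)N4)cc3)CC2)C(=O)O1`) gives 86 mL/min/kg and compound 2 (`O=C(c1ccc(C[C@@H]2CC[C@H]([C@H](O)c3ccccc3)N2)cc1)N1C[C@@H]2[C@H](C1)[C@H]2c1nnco1`) gives 62 mL/min/kg as a pair within the scatter of each other, so compound 2 stands level with compound 1. Compound 3 (`Cn1nnc([C@H]2[C@@H]3CN(C(=O)c4ccc(C[C@@H]5CC[C@H]([C@H](O)c6ccccc6)N5)cc4)C[C@@H]32)n1`) carries 2-methyl-2H-tetrazol-5-yl in place of 1,3,4-oxadiazol-2-yl on a saturated ring carbon and is otherwise the same as compound 2. Within the data shown here, no measured pair shows a step of this kind, so in this assay no change beyond the scatter is expected in either direction. The expected step (a 1.1-fold lower number from compound 2 to compound 3 (0.03 log units; within the scatter)) stays within the scatter. Compound 3 is estimated at 58 mL/min/kg in a range of 35 mL/min/kg to 90 mL/min/kg for the measurement to come.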

Compound 3, clearance: 29 mL/min/kg
The estimate for compound 3 lay 2.0-fold (0.30 log units) above the measured number, and the stated range ends above it.
By their numbers in this assay, from the lowest: compound 3; then compounds 2 and 1 (each within the scatter of the next).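

On the saturated ring carbon of the three-membered ring, the choice of five-membered aromatic ring matters in this assay: 2-methyl-2H-tetrazol-5-yl in place of 1,3,4-oxadiazol-2-yl gives a 2.1-fold lower number from compound 2 to compound 3 (0.33 log units; beyond the scatter) as the first step read at this position. The step is modest, yet it shows that this position is not silent for clearance. Nothing at hand gives a reason for the step. Still open, going by these compounds, is how an amine or a carboxylic acid on this carbon would compare, and whether the step carries over to other amide partners such as that of compound 1.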